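The source may hold more compounds than are shown below. What is called first, only, known or untested is meant among the compounds shown, and "the series" means these compounds.

Measured compounds:
compound 1, `Cc1cc(Sc2ccc(N)cc2)cn2c(CSCCc3ccccc3)cnc12`: 20 ug/mL
compound 2, `Cc1cc(N2CCN(C)CC2)c2ncc(CSCCc3ccccc3)n2c1`: "not determined" (no result reported)

In an ADME assay on HEL cells (Homo sapiens) for cytotoxicity, with a stated time of 3 days (a higher number here means that more compound is tolerated, a lower number that less compound is tolerated), compound 1 gives 20 ug/mL. In this assay compound 2 gives "not determined" (no result reported), so no number was reported for it and it stands nowhere on the scale shown here. Compound 3, `Cc1cc(Sc2ccc(O)cc2)c2ncc(CSCCc3ccccc3)n2c1`, differs from compound 2 in one place: (4-hydroxyphenyl)sulfanyl in place of 4-methylpiperazin-1-yl on an aromatic carbon. With no value for compound 2, the size and direction of the step to compound 3 in this assay cannot be set from that pair. Among the compounds with values here, the only anchor is compound 1, which gives 20 ug/mL in this assay. Compound 3 is expected to lie near that, estimated at 20 ug/mL, within 7 ug/mL to 60 ug/mL.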

Compound 3, minimum cytotoxic concentration: > 100 ug/mL
Compound 3: a limit, no number; the forecaster's own chance of this, stated with the estimate: 30%; at least 5.0-fold (0.69 log units) between middle value and limit.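

In this assay compound 3 gives > 100 ug/mL, a limit and not a number. Within the data shown here, no step from compound 2 to compound 3 can be read, as compound 2 has no number here. The compounds shown leave open how 4-methylpiperazin-1-yl and (4-hydroxyphenyl)sulfanyl compare in this assay.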